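The source may report more compounds than this note shows. Statements on the series, on what has been measured and on what is new or still open speak of the compounds shown alone.

Measured in an ADME assay on microsomes from liver (Homo sapiens) for metabolic stability, read by LC-MS, using NADPH, with a stated time of 10 min, tested at 0.1 uM; a higher number here means faster removal of the compound, a lower number slower removal:

Compound 1 `COc1ccc(F)cc1N1C(=O)CSC1c1cccc(C(=O)NCCCCc2ccccc2)c1`: 1250 mL.min-1.g-1
Compound 2 `C#Cc1cc(C(=O)NCCCCc2ccccc2)cc(C2SCC(=O)N2c2ccccc2OC)c1`: 1730 mL.min-1.g-1

For the measured compounds named here, these two numbers lie within the usual scatter of each other, so compound 1 cannot be ranked against compound 2, the only other compound measured so far. The next compound, compound 3 `C#Cc1cccc(N2C(=O)CSC2c2cccc(C(=O)NCCCCc3ccccc3)c2)c1`, differs from compound 1 in one place: 3-ethynylphenyl in place of 5-fluoro-2-methoxyphenyl on an amide-type nitrogen in a ring. In words, 3-ethynylphenyl stands in place of 5-fluoro-2-methoxyphenyl on an amide-type nitrogen in a ring, while the rest of the molecule stays the same.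

Going by the values given here, no measured pair differs in only one place, so the data show no direct effect of this change. With no such evidence, the working expectation in this assay is no shift beyond the scatter, and no direction can be predicted with confidence. The estimated step is a 1.2-fold higher number from compound 1 to compound 3 (0.08 log units; within the scatter). Compound 3 is expected to give about 1500 mL.min-1.g-1, with an estimated range of 750 mL.min-1.g-1 to 3000 mL.min-1.g-1.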

Compound 3, intrinsic clearance in microsomes: 751 mL.min-1.g-1
Compound 3: the middle estimate sits 2.0-fold (0.30 log units) above what was measured; the measured number falls inside the stated range.
By their numbers in this assay, from the lowest: compounds 3, 1 and 2 (each within the scatter of the next, the first and the last beyond it).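

In this assay, for the compounds shown here, the pair gives the first direct reading at this position on the amide-type nitrogen: 3-ethynylphenyl in place of 5-fluoro-2-methoxyphenyl gives a 1.7-fold lower number from compound 1 to compound 3 (0.22 log units; within the scatter) and so the two compounds cannot be ranked. For this one pair, then, exchanging a ring that carries oxygen and fluorine for an all-carbon ring with a triple bond produces no difference that can be told from the scatter. No separate measurement is available to explain this result.

From the compounds shown here alone, it remains open whether a more different group here, such as a pyridine ring or a phenyl ring carrying an amine or a carboxylic acid, would shift the number beyond the scatter. Going by these compounds alone, the single pair also cannot show what the fluorine, the methoxy group or the ethynyl group does on its own.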